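Fluoro for Methyl on the Shared Core

A few compounds are considered here, and "the series" means these few. Any claim that something is new, unique, unknown or untested is made for them only; others in the source may bear on it.

Compound 1, `N#CC1=C(N)OC(c2c[nH]c3ccccc23)=C(C#N)C1c1ccc(Br)cc1`, gives 14.2% in a functional assay, tested at 50 ug/mL; on this read-out lower numbers stand for a weaker effect and higher numbers for a stronger effect at the one concentration tested.
Compound 2, `COc1ccc(C2C(C#N)=C(N)OC(c3c[nH]c4ccccc34)=C2C#N)cc1OC`, gives 14.5%.
Compound 3, `Cc1ccc(C2C(C#N)=C(N)OC(c3c[nH]c4ccccc34)=C2C#N)cc1`, gives 5.2%.

Compound 3 holds the lowest of the three numbers, but its steps to both neighbours fall within the usual scatter: a number 9 percentage points lower from compound 1 to compound 3 (within the scatter) and a number 9.3 percentage points lower from compound 2 to compound 3 (within the scatter). The remaining step, a number 0.3 percentage points higher from compound 1 to compound 2 (within the scatter), is likewise within the scatter, so across these three compounds the read-out barely moves.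

Compound 4, `N#CC1=C(N)OC(c2c[nH]c3ccccc23)=C(C#N)C1c1ccc(F)cc1`, has not yet been measured. It differs from compound 3 in one place:

fluoro in place of methyl on an aromatic carbon

Going by the values given here, the step that bears most directly on this change is the one from compound 1 to compound 3, where a bromo and a methyl were exchanged on the same aromatic carbon without any shift beyond the scatter. The exchange of the whole 4-methylphenyl for 3,4-dimethoxyphenyl, from compound 2 to compound 3, was equally flat. Nothing among the three measured compounds suggests that a fluoro on that aromatic carbon should behave differently, so compound 4 is expected to show a number 4.8 percentage points higher from compound 3 to compound 4 (within the scatter), a change no larger than the scatter. Compound 4 is therefore estimated at 10%, with a range from 0% to 25%.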

Compound 4, a percentage reported as activity, at one concentration (the size of the read-out at that concentration, not a potency): 8.4%
The estimate for compound 4 lay 1.6 percentage points above the measured number; the measured number falls inside the stated range.
By their numbers in this assay, from the lowest: compounds 3, 4, 1 and 2 (each within the scatter of the next).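

Fluoro on this aromatic carbon, para to a large group, leaves the read-out in this assay unchanged within the scatter: the exchange for methyl gives a number 3.2 percentage points higher from compound 3 to compound 4 (within the scatter), and the exchange for bromo gives a number 5.8 percentage points lower from compound 1 to compound 4 (within the scatter). The wider exchange on the saturated ring carbon, 4-fluorophenyl in place of 3,4-dimethoxyphenyl, likewise gives a number 6.1 percentage points lower from compound 2 to compound 4 (within the scatter), so this read-out does not separate fluoro, methyl and bromo at this position, nor any of these three rings from the 3,4-dimethoxyphenyl ring. No measurement here offers an explanation for this flat result.

Still open, going by these compounds, is whether a group of another kind on this aromatic carbon, such as an amine or a carboxylic acid, would move the number beyond the scatter, and whether exchanging a nitrile on the shared core for an amide would do so. Because each compound is described at a single concentration, the numbers also leave open how these compounds would compare at other concentrations, or whether any difference among them would emerge there.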